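Benzimidazole to pyridine on the shared core

This account rests on a few compounds, and the source may have more. Where it says the series, first, only, none or still open, it means among the compounds named here.

Measured compounds:
compound 1, `Cc1ccc(-c2cnc(C)n2C)cc1NC(=O)c1ccc(OCc2ccccn2)cc1`, in a physicochemical assay for lipophilicity (a lower number here means a more polar compound, a higher number a more lipophilic compound), gives 2.8.
compound 2, `Cc1cc(C)c(-c2nc3ccccc3[nH]2)cc1NC(=O)c1ccc(OCc2ccccn2)cc1`, in this assay reaches only a limit, > 3.5.

The account follows the step from compound 2 to compound 3. Compound 2 stands at the upper edge of what the numbers show: its value is a limit of the assay and not a number, as noted in the limit of > 3.5 in this assay, at which 1 of the 2 values shown sits. Compound 1 gives a plain number below that edge.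

Compound 3, `Cc1cc(C)c(-c2ccccn2)cc1NC(=O)c1ccc(OCc2ccccn2)cc1`, is not yet measured. It differs from compound 2 in one place: pyridin-2-yl in place of 1H-benzimidazol-2-yl on an aromatic carbon. Going by the values given here, no step between measured compounds is given, so the size of this step cannot be read from the data. The author expects the step from compound 2 to compound 3 to be downward, a number at least 0.20 log units lower from compound 2 to compound 3 (that floor lies within the scatter), since what leaves is the larger group and what enters the smaller one, while the number may still land near or above the limit. For compound 3 the estimate is 3.3, within the range 2.7 to 3.9.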

Compound 3, distribution coefficient: > 3
Compound 3 was reported as a limit (the forecaster's own chance of this, stated with the estimate: 35%); the middle value lies beyond the limit too.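

In this assay compound 3 gives > 3, a limit of the assay and not a number. Going by these compounds alone, compound 2, at > 3.5, is also a limit, so no step from compound 2 to compound 3 can be read. The compounds shown leave open how far, and in which direction, pyridin-2-yl in place of 1H-benzimidazol-2-yl moves the distribution coefficient.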